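A few compounds are considered here, and "the series" means these few. Any claim that something is new, unique, unknown or untested is made for them only; others in the source may bear on it.

Measured compounds:
compound 1 `COC(=O)C(=N)/C=C(\O)c1ccccc1`, 3%
compound 2 `COC(=O)C(=N)/C=C(\O)c1ccccc1Cl`, 31%
compound 3 `N/C(=C\C(=O)c1ccccc1)C(=O)O`, 17%

In an assay for inhibition of kynurenine 3-monooxygenase (Rattus norvegicus), tested at 10 uM (a higher number here means more inhibition at the concentration tested (going by the name of the read-out), a lower number less inhibition), compound 1 gives 3% and compound 2 gives 31%; the change between them is chloro in place of hydrogen on an aromatic carbon, and it made a number 28 percentage points higher from compound 1 to compound 2 (beyond the scatter). Compound 3 gives 17% in this assay; the difference between the core of compound 3 and the core of compound 1 is not broken down here.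

Compound 4 `N/C(=C\C(=O)c1ccccc1Cl)C(=O)O` is not yet measured. It differs from compound 3 by chloro in place of hydrogen on an aromatic carbon. The place line differs from the earlier one only in the size of the neighbouring group, ortho to a group of 8 heavy atoms rather than 9, so this is the same kind of change, not the same change. The step expected is a number 23 percentage points higher from compound 3 to compound 4 (beyond the scatter), because the same kind of change gave a number 28 percentage points higher from compound 1 to compound 2 (beyond the scatter). In this assay compound 4 is expected to give about 40%, with a likely range of 20% to 62%.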

Compound 4, a percentage reported as inhibition, at one concentration (the size of the read-out at that concentration, not a potency): 19%
Compound 4: middle estimate off by 21 percentage points, on the high side; measured number outside the range, below it.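

In this assay, chloro in place of hydrogen on an aromatic carbon does not carry over with one size from the core of compound 1 to the core of compound 3: the same change on two cores in this assay, a number 28 percentage points higher (beyond the scatter) from compound 1 to compound 2 and a number 2 percentage points higher (within the scatter) from compound 3 to compound 4, 26 percentage points apart, beyond the scatter of two such steps On the core of compound 3 the change gives a number 2 percentage points higher from compound 3 to compound 4 (within the scatter), so the larger step on the core of compound 1 cannot be used as a fixed increment in this series. These two pairs show that the size of the step differs with the core, but not which part of the cores accounts for that.

Open, on these data alone, is whether bromo, methoxy or a nitrile, each put where chloro stands, would also give steps that differ between the two cores. Also open, as far as these compounds go, is how an amide in place of the ester or acid would affect the step.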